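The source may hold more compounds than are shown below. What is called first, only, known or untested is meant among the compounds shown, and "the series" means these compounds.

Measured compounds in the series so far:

Compound 1, `CCCCCc1c(C(C)C)nc(C(C)C)c(CO)c1-c1ccccc1NC(C)=O`: 13%
Compound 2, `CCCCCc1c(C(C)C)nc(C(C)C)c(CO)c1-c1cccc(Cl)c1`: 49%
Compound 3, `CCCCCc1c(C(C)C)nc(C(C)C)c(CO)c1-c1ccccc1CO`: 44%

In an assay on CHO cells for inhibition of Glucagon receptor (Homo sapiens), tested at 20 uM (a higher number here means more inhibition at the concentration tested (going by the name of the read-out), a lower number less inhibition), compound 1 gives 13% and stands lowest of the three numbers. Its nearest neighbour is compound 3, which in this assay gives 44%; the furthest is compound 2, which in this assay gives 49%. Among the measured compounds shown here, the one single-point step from compound 1 is a number 31 percentage points higher from compound 1 to compound 3 (beyond the scatter), a large rise. The step of a number 5 percentage points lower from compound 2 to compound 3 (within the scatter) shows that the two measured pendant aryl groups of compound 2 and compound 3 sit in the same region of the read-out.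

The next compound, compound 4, `CCCCCc1c(C(C)C)nc(C(C)C)c(CO)c1-c1ccccc1C`, differs from compound 1 as follows: methyl in place of acetamido on an aromatic carbon. For the measured compounds named here, the only measured step that bears on it is the removal of the acetamido from compound 1, which gave a large increase when hydroxymethyl entered in its place. Methyl is a different replacement with no hydrogen-bond donor or acceptor, and there is no direct measurement of such a change in this series, so the size carries over only loosely. A rise beyond the scatter is nevertheless expected, and the step from compound 1 to compound 4 is estimated at a number 27 percentage points higher from compound 1 to compound 4 (beyond the scatter).

Compound 4 is therefore expected to give about 40%, with a range from 15% to 65%.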

Compound 4, a percentage reported as inhibition, at one concentration (the size of the read-out at that concentration, not a potency): 33%
Compound 4: the middle estimate sits 7 percentage points above what was measured, and the stated range covers the measured number.
By their numbers in this assay, from the lowest: compound 1; then compound 4; then compounds 3 and 2 (each within the scatter of the next).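

Methyl, with 0 hydrogen-bond donors and 0 hydrogen-bond acceptors, also improves on acetamido at this place on the aromatic ring, giving a number 20 percentage points higher from compound 1 to compound 4 (beyond the scatter) in this assay, so the rise away from compound 1 does not require the hydroxy of compound 3. That hydroxy still counts on the saturated chain carbon, with a number 11 percentage points lower from compound 3 to compound 4 (beyond the scatter) on its loss, and the aryl groups now separate, with a number 16 percentage points lower from compound 2 to compound 4 (beyond the scatter), although compound 2 and compound 3 lie within the scatter of each other. The compounds shown carry no measurement that accounts for any of these steps.

Still open, as far as these compounds go, is whether a chloro on the same aromatic carbon as the methyl of compound 4 would match compound 2, since 2-methylphenyl and 3-chlorophenyl differ in both the group and its place on the ring. Also open, from the compounds shown here alone, is how an amine, a carboxylic acid or a longer hydroxyalkyl chain on that aromatic carbon would compare with the hydroxymethyl of compound 3 and the methyl of compound 4.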